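Flipping One Stereocentre on the Fluorocyclopropyl Amide

The source may hold more compounds than are shown below. What is called first, only, known or untested is meant among the compounds shown, and "the series" means these compounds.

Three amides built on a shared core have been measured in an assay on CHO cells for agonist activity at Neuronal acetylcholine receptor; alpha3/alpha6/beta2/beta3 (Homo sapiens), read by FLIPR and calcium flux; a lower number here means that less compound is needed, a higher number that more compound is needed for the effect. Compound 1 `CC(=O)N1CC2CC(C1)N2` gives 750 nM, compound 2 `CC(C)C(=O)N1CC2CC(C1)N2` gives 16000 nM, and compound 3 `O=C([C@H]1C[C@H]1F)N1CC2CC(C1)N2` gives 62 nM. Compound 3 stands lowest of the three: the step of a 12-fold lower number from compound 1 to compound 3 (1.08 log units; beyond the scatter) is large, the step of a 260-fold lower number from compound 2 to compound 3 (2.41 log units; beyond the scatter) is larger still, and the step of a 21-fold higher number from compound 1 to compound 2 (1.33 log units; beyond the scatter) shows that exchanging one group on the carbonyl carbon for another can also move the number sharply the other way. Compound 4 `O=C([C@H]1C[C@@H]1F)N1CC2CC(C1)N2` keeps every atom and bond of compound 3; (the two compounds have the same atoms and bonds; at least one stereo element is drawn with a configuration in one of them and without one in the other: 1 of 4 stereo elements differ; a stereocentre at a saturated ring carbon is drawn R in compound 3 and S in compound 4). Going by the values given here, none of the measured steps concerns a change of configuration by itself; each of them swaps one whole group on the carbonyl carbon for a different one, and all three were large. What they do show is that the group on the carbonyl carbon is where the numbers have moved most, so a flipped centre inside the 2-fluorocyclopropyl group could matter, yet the data give no direction for it. Compound 4 is therefore expected to remain near compound 3, with a wide range, and the step of a 1.9-fold higher number from compound 3 to compound 4 (0.29 log units; within the scatter) is expected to be modest. On that basis compound 4 is estimated at 120 nM, between 30 nM and 500 nM.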

Compound 4, half-maximal effective concentration: 620 nM
Beside the measured number, compound 4's estimate is 5.2-fold (0.71 log units) below it, outside the stated range (above it).
By their numbers in this assay, from the lowest: compound 3; then compounds 4 and 1 (each within the scatter of the next); then compound 2.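

In this assay the drawn configuration at one saturated ring carbon of the 2-fluorocyclopropyl group matters by itself: with the same atoms and bonds there is a 10-fold higher number from compound 3 to compound 4 (1.00 log units; beyond the scatter), a step as clear as some of those made by exchanging a whole group. The edge of the 2-fluorocyclopropyl group over methyl therefore belongs to the form drawn in compound 3 and not to the group in every form, since a 1.2-fold lower number from compound 1 to compound 4 (0.08 log units; within the scatter) leaves no separation between the methyl amide and compound 4, while a 26-fold lower number from compound 2 to compound 4 (1.41 log units; beyond the scatter) shows that compound 4 still stands well clear of the isopropyl amide. This reading of the flipped centre carries one caution: the fact that one of compounds 3 and 4 is drawn with a defined configuration and the other without, at the place where they differ.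

On these data alone, whether the fluorine itself is needed stays open, and a plain cyclopropyl group or a 2-methylcyclopropyl group on the carbonyl carbon would speak to that. Also open, as far as these compounds go, is whether the same preference for one configuration would hold with a 2-chlorocyclopropyl group, or what the remaining arrangements of the 2-fluorocyclopropyl group would give.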